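Ring Size at the Ether Oxygen in Two Growth Inhibitor Series

The compounds below may be only part of what the source reports. "The series", "measured", "known", "first", "only" and "open" are said of these compounds alone.

Of the compounds shown here, three have been tested in a functional assay on MCF7 cells (Homo sapiens) for inhibition, read by sulforhodamine B assay, with a stated time of 48 h; on this read-out higher numbers stand for weaker inhibition of growth and lower numbers for stronger inhibition of growth. Compound 1 `c1cc(NC2=NCCO2)cc(OC2CCCC2)c1` and compound 2 `c1cc(NC2=NCCO2)cc(OC2CCCCC2)c1` share one core; compound 3 `O=C(CCl)NC(=O)Nc1ccc(OC2CCCC2)cc1` is built on another, and the difference between the two cores is not broken down here. In this assay compound 1 gives 62100 nM, compound 2 gives 15900 nM, and compound 3 gives 3900 nM, the lowest of the three numbers.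

The change from compound 1 to compound 2 is cyclohexyl in place of cyclopentyl on an oxygen on an aromatic ring, and it brought a 3.9-fold lower number from compound 1 to compound 2 (0.59 log units; beyond the scatter). Compound 4 `O=C(CCl)NC(=O)Nc1ccc(OC2CCCCC2)cc1` is not yet measured; it carries the same change on the core of compound 3: cyclohexyl in place of cyclopentyl on an oxygen on an aromatic ring. Among the compounds shown this change occurs twice, once measured and once still to be measured, and the surroundings of the place are the same in both cases.

For the measured compounds named here, whether the step will carry over from one core to the other cannot be checked, since the only measured example stands on a different core. Going by the values given here, that example is nonetheless the sole guide, so a step of roughly the same direction and size is expected, and the estimated step is a 3.0-fold lower number from compound 3 to compound 4 (0.48 log units; beyond the scatter), resting on a 3.9-fold lower number from compound 1 to compound 2 (0.59 log units; beyond the scatter). The estimate for compound 4 in this assay is therefore 1300 nM, expected to fall between 500 nM and 3500 nM, with the upper end allowing for the step not transferring in full.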

Compound 4, concentration for 50% growth inhibition: 4700 nM
Compound 4: the middle estimate sits 3.6-fold (0.56 log units) below what was measured; the whole stated range lies below it.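

On the core of compound 3, cyclohexyl in place of cyclopentyl on the oxygen gives a 1.2-fold higher number from compound 3 to compound 4 (0.08 log units; within the scatter) in this assay, so this test cannot tell these two compounds apart. The benefit seen on the first core therefore did not carry over to the second, and the two steps clearly disagree: the same change on two cores in this assay, a 3.9-fold lower number (0.59 log units; beyond the scatter) from compound 1 to compound 2 and a 1.2-fold higher number (0.08 log units; within the scatter) from compound 3 to compound 4, 4.7-fold (0.67 log units) apart, beyond the scatter of two such steps

This shows that, within these two pairs, the effect of the swap depends on the core it sits on, so a step measured on one core is a poor guide to the other. It does not show which feature of the cores is responsible, and with a single pair on each core it gives no general rule for the series.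

The compounds shown carry only cyclopentyl and cyclohexyl on the oxygen, so it remains open how a methyl group, a longer chain such as butyl, or a ring bearing an amine would behave on either core. Also open, from the compounds shown here alone, is whether the two cores would part ways again for such groups, or whether this disagreement is confined to the step from cyclopentyl to cyclohexyl.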